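The source may report more compounds than this note shows. Statements on the series, on what has been measured and on what is new or still open speak of the compounds shown alone.

Measured compounds:
Compound 1, `CSc1c(SCC#CCO)cnc2ccccc12`, 13.9 ug/mL
Compound 2, `C#CCSc1c(SCC#CCO)cnc2ccccc12`, 2.7 ug/mL
Compound 3, `C#CCSc1cnc2ccccc2c1[Se]CC#CCO`, 3.2 ug/mL

Of the compounds shown here, three have been measured in a functional assay on CCRF-CEM cells (Homo sapiens) for cytotoxicity, read by sulforhodamine B assay, with a stated time of 72 h; on this read-out higher numbers stand for weaker inhibition and lower numbers for stronger inhibition. Compound 2 gives 2.7 ug/mL, and compound 1, which differs from it by hydrogen in place of ethynyl on a saturated chain carbon bound to a sulfur, gives 13.9 ug/mL. That change made a step of a 5.1-fold higher number from compound 2 to compound 1 (0.71 log units; beyond the scatter).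

Compound 3, with the structure `C#CCSc1cnc2ccccc2c1[Se]CC#CCO`, gives 3.2 ug/mL in this assay. The difference between the core of compound 3 and the core of compound 2 is not broken down here; their two values lie within the usual scatter of each other, so nothing is read into their order.

Compound 4, `CSc1cnc2ccccc2c1[Se]CC#CCO`, has not yet been measured. It differs from compound 3 by hydrogen in place of ethynyl on a saturated chain carbon bound to a sulfur. This is the same change that was made from compound 2 to compound 1, and it occurs twice among the compounds shown. Because the earlier step was a 5.1-fold higher number from compound 2 to compound 1 (0.71 log units; beyond the scatter), the step from compound 3 to compound 4 is expected to be of a similar size, about a 4.7-fold higher number from compound 3 to compound 4 (0.67 log units; beyond the scatter). The expectation rests on a single precedent, so the range is kept wide. Compound 4 is therefore estimated to give about 15 ug/mL in this assay, with the likely range running from 6 ug/mL to 40 ug/mL.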

Compound 4, concentration for 50% inhibition: 0.5 ug/mL
Estimate against measurement, compound 4: 30-fold (1.48 log units) above; the whole stated range lies above it.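

Changing propargylsulfanyl to methylsulfanyl did not carry over from one core to the other in this assay: here it gave a 6.4-fold lower number from compound 3 to compound 4 (0.81 log units; beyond the scatter), which runs opposite to the earlier step. Set side by side, the two steps differ in direction, and the gap between them is larger than scatter alone would explain: the same change on two cores in this assay, a 5.1-fold higher number (0.71 log units; beyond the scatter) from compound 2 to compound 1 and a 6.4-fold lower number (0.81 log units; beyond the scatter) from compound 3 to compound 4, 33-fold (1.52 log units) apart, beyond the scatter of two such steps. This shows that, for these two pairs, the outcome of the change depends on the core that carries it, so the step measured on one core could not be transferred to the other; it does not show which feature of the cores is responsible, and two pairs give no rule for any further core.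

The compounds shown leave open whether another group in the same place, such as ethylsulfanyl or benzylsulfanyl, would follow the course seen on the core of compound 2 or the one seen on the core of compound 3. They also leave open whether compound 4, at 0.5 ug/mL, marks a result particular to the methylsulfanyl group or one shared by other small groups on that core.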